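A few compounds are considered here, and "the series" means these few. Any claim that something is new, unique, unknown or untested is made for them only; others in the source may bear on it.

Measured compounds in an assay on HEK293 cells for binding affinity to Neuronal acetylcholine receptor; alpha4/beta2 (Homo sapiens); a lower number here means a stronger inhibitor, a higher number a weaker inhibitor:
compound 1 `c1ccc(-n2cnc3cc4c(cc32)C2CNCC4C2)cc1` — 0.14 nM
compound 2 `Cn1cnc2cc3c(cc21)C1CNCC3C1` — 0.75 nM
compound 3 `Cc1nc2cc3c(cc2n1C)C1CNCC3C1` — 0.31 nM

Compound 2 stands highest of the three numbers; its nearest neighbour is compound 3, at a 2.4-fold lower number from compound 2 to compound 3 (0.38 log units; beyond the scatter), and the furthest is compound 1, at a 5.4-fold higher number from compound 1 to compound 2 (0.73 log units; beyond the scatter). Compound 4 `c1nc2cc3c(cc2[nH]1)C1CNCC3C1` is unmeasured; it differs from compound 2 by hydrogen in place of methyl on an aromatic nitrogen. The step that bears on this is the one at the same ring nitrogen, a 5.4-fold higher number from compound 1 to compound 2 (0.73 log units; beyond the scatter), where a smaller group in place of a larger one raised the number. Going on to hydrogen is expected to move the number little, perhaps a modest rise, because the earlier step was a 5.4-fold higher number from compound 1 to compound 2 (0.73 log units; beyond the scatter). Compound 4 is therefore estimated at 1 nM in this assay, within 0.3 nM to 3 nM, a step of a 1.3-fold higher number from compound 2 to compound 4 (0.12 log units; within the scatter).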

Compound 4, inhibition constant: 0.15 nM
Compound 4: middle estimate off by 6.7-fold (0.82 log units), on the high side; the measured number lies below the stated range.
By their numbers in this assay, from the lowest: compounds 1 and 4 (each within the scatter of the next); then compound 3; then compound 2.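

In this assay hydrogen in place of methyl on the aromatic nitrogen lowers the number (a 5.0-fold lower number from compound 2 to compound 4 (0.70 log units; beyond the scatter)), so the number at this nitrogen does not follow group size. Of the three groups seen there, methyl alone stands apart, while hydrogen and phenyl give matching numbers (a 1.1-fold higher number from compound 1 to compound 4 (0.03 log units; within the scatter)). No measured evidence accounts for this behaviour of methyl. Still open, on these data alone, is how ethyl, benzyl or 2-hydroxyethyl on this nitrogen would read, and whether hydrogen would also lower the number with the methyl on the aromatic carbon of compound 3 in place.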